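This account rests on a few compounds, and the source may have more. Where it says the series, first, only, none or still open, it means among the compounds named here.

In a functional assay on HepG2 cells (Homo sapiens) for cytotoxicity, read by MTT assay, with a stated time of 24 h (a lower number here means a stronger inhibitor, a higher number a weaker inhibitor), compound 1 (`CN1C/C(=C\c2ccc(C(C)(C)C)cc2)C(=O)/C(=C/c2ccccc2F)C1`) gives 9120 nM, compound 2 (`CN1C/C(=C\c2ccc(C(F)(F)F)cc2)C(=O)/C(=C/c2ccccc2F)C1`) gives 4140 nM and compound 3 (`CN1C/C(=C\c2ccc(C#N)cc2)C(=O)/C(=C/c2ccccc2F)C1`) gives 590 nM, the lowest of these three numbers. Compound 4 (`CN1C/C(=C\c2ccc(C#N)cc2)C(=O)/C(=C/c2ccc(Cl)cc2Cl)C1`) carries 2,4-dichlorophenyl in place of 2-fluorophenyl on a double-bonded chain carbon bound to a double-bonded ring carbon. The measured steps, a 2.2-fold lower number from compound 1 to compound 2 (0.34 log units; beyond the scatter), a 7.0-fold lower number from compound 2 to compound 3 (0.85 log units; beyond the scatter) and a 15-fold lower number from compound 1 to compound 3 (1.19 log units; beyond the scatter), range from modest to large, but all keep the 2-fluorophenyl, so none tests this change directly. Within the data shown here, they show only that single exchanges can move the number in this small set. With compound 3 already lowest, a modest rise is the expected outcome in this assay, a 1.7-fold higher number from compound 3 to compound 4 (0.23 log units; within the scatter). The estimate for compound 4 is 1000 nM, within a range of 300 nM to 3500 nM.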

Compound 4, half-maximal inhibitory concentration: 6250 nM
Estimate against measurement, compound 4: 6.3-fold (0.80 log units) below; measured number outside the range, above it.
By their numbers in this assay, from the lowest: compound 3; then compounds 2, 4 and 1 (each within the scatter of the next, the first and the last beyond it).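

In this assay, 2,4-dichlorophenyl in place of 2-fluorophenyl on a double-bonded chain carbon bound to a double-bonded ring carbon brings an 11-fold higher number from compound 3 to compound 4 (1.03 log units; beyond the scatter), a large step. Among these compounds, all the earlier steps kept 2-fluorophenyl, so this is the first sign that the number also depends on the group at this place. Nothing shown here explains the rise. The compounds shown do not separate the loss of fluorine from the gain of either chlorine, and they leave open how a plain phenyl or a pyridine would behave at this carbon.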